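This account rests on a few compounds, and the source may have more. Where it says the series, first, only, none or still open, it means among the compounds named here.

The measured compounds and their values in a functional assay on U-251 cells (Homo sapiens) for inhibition, read by sulforhodamine B assay, with a stated time of 48 h; a higher number here means a weaker inhibitor of growth, a lower number a stronger inhibitor of growth:

Compound 1 `O=C1C=COC(/C=C/c2ccc(C(F)(F)F)cc2)C1` gives 38.6 uM.
Compound 2 `COc1ccc(/C=C/C2CC(=O)C=CO2)cc1` gives 152 uM.
Compound 3 `O=C1C=CCC(/C=C/c2ccc(C(F)(F)F)cc2)N1` gives 130 uM.

Compound 1 and compound 2 share a core and differ in one place, (methoxy in place of trifluoromethyl on an aromatic carbon). This change produced a 3.9-fold higher number from compound 1 to compound 2 (0.60 log units; beyond the scatter), a step beyond the usual scatter. Compound 3 carries a different core; the difference between the two cores is not broken down here, and compound 3 sits close to compound 2 while its number is clearly higher than that of compound 1.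

Compound 4 `COc1ccc(/C=C/C2CC=CC(=O)N2)cc1` is not yet measured. It relates to compound 3 exactly as compound 2 relates to compound 1: methoxy in place of trifluoromethyl on an aromatic carbon, with the place described in the same words, so the change is the same. Going by the values given here, because the single measured instance of this change gave a 3.9-fold higher number from compound 1 to compound 2 (0.60 log units; beyond the scatter), a step of similar size is expected from compound 3 to compound 4, namely a 3.1-fold higher number from compound 3 to compound 4 (0.49 log units; beyond the scatter). On that basis compound 4 is estimated at 400 uM in this assay , with a range from 170 uM to 900 uM; this rests on one pair only, so the expectation is uncertain.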

Compound 4, concentration for growth inhibition (reported as GI): 981 uM
Estimate against measurement, compound 4: 2.5-fold (0.39 log units) below; the measured number lies above the stated range.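

In this assay, putting methoxy in place of trifluoromethyl on the second core gave a 7.5-fold higher number from compound 3 to compound 4 (0.88 log units; beyond the scatter), so the change moved the number the same way on both cores, towards weaker inhibition of growth. Set side by side, the two steps differ by no more than repeated measurements would be expected to: the same change on two cores in this assay, a 3.9-fold higher number (0.60 log units; beyond the scatter) from compound 1 to compound 2 and a 7.5-fold higher number (0.88 log units; beyond the scatter) from compound 3 to compound 4, 1.9-fold (0.28 log units) apart, within the scatter of two such steps. For these two pairs, then, the change carried over from one core to the other in direction and, within the scatter, in size, but two pairs cannot show that it would carry over to any further core, and they do not explain why the methoxy compounds give the higher numbers.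

The compounds shown leave open how other groups at this same place on the aromatic ring would behave on either core, such as a chlorine atom, an amine or a carboxylic acid. They also leave open whether the same steps would appear in any test other than this assay.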